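Moving a halogen on the phenyl ring of an amidoxime

The source may hold more compounds than are shown below. What is called first, only, known or untested is meant among the compounds shown, and "the series" means these compounds.

Compound 1, `O=[N+]([O-])c1ccc(N/C(=N\O)c2ccccc2F)c2nonc12`: 110000 nM
Compound 2, `O=[N+]([O-])c1ccc(N/C(=N\O)c2ccccc2Br)c2nonc12`: 25000 nM

Within the data shown here, in an assay on isolated protein for inhibition of Tryptophan 2,3-dioxygenase (Homo sapiens), read by spectrophotometry, with a stated time of 1 h (a lower number here means a stronger inhibitor, a higher number a weaker inhibitor), compound 2 gives the lower of the two numbers, with compound 1 the only comparison. Among the measured compounds shown here, the one measured step, a 4.4-fold lower number from compound 1 to compound 2 (0.64 log units; beyond the scatter), swaps the halogen while keeping its place. For the measured compounds named here, compound 3, `O=[N+]([O-])c1ccc(N/C(=N\O)c2cccc(F)c2)c2nonc12`, differs from compound 2 by 3-fluorophenyl in place of 2-bromophenyl on a carbon with a double bond to nitrogen, so both the halogen and its place change at once, and no measured step covers such a move. Because compound 1 gives 110000 nM, a number between the two is expected, with wide uncertainty. Compound 3 is estimated at 60000 nM, from 20000 nM to 200000 nM. That change is expected to amount to a 2.4-fold higher number from compound 2 to compound 3 (0.38 log units; beyond the scatter).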

Compound 3, half-maximal inhibitory concentration: 45000 nM
Compound 3: middle estimate off by 1.3-fold (0.12 log units), on the high side, and the stated range covers the measured number.
By their numbers in this assay, from the lowest: compounds 2 and 3 (each within the scatter of the next); then compound 1.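

In this assay moving the fluorine from 2-fluorophenyl to 3-fluorophenyl gives a 2.4-fold lower number from compound 1 to compound 3 (0.39 log units; beyond the scatter) and so the place of the halogen on this ring counts, not only which halogen it is. Exchanging 2-bromophenyl for 3-fluorophenyl gives a 1.8-fold higher number from compound 2 to compound 3 (0.26 log units; within the scatter) and so these two groups cannot be told apart in this assay. Nothing available explains either result.

Going by these compounds, whether 3-bromophenyl would give a lower number than either group remains open. So does the effect of a non-halogen on this ring, such as an amine or a carboxylic acid.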